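The source may hold more compounds than are shown below. What is called first, only, known or untested is meant among the compounds shown, and "the series" means these compounds.

Working notes on the series. Of the compounds shown here, three sharing one core have been measured in a functional assay for antagonist activity at transient receptor potential cation channel subfamily V member 1 (Homo sapiens); on this read-out higher numbers stand for weaker inhibition and lower numbers for stronger inhibition. Compound 1 `COCc1nc(Nc2ccc(C(F)(F)F)cc2)c2ccc(-c3ncccc3C(F)(F)F)cc2n1` gives 1.5 nM in this assay. Compound 2 `O=C(O)COCc1nc(Nc2ccc(C(F)(F)F)cc2)c2ccc(-c3ncccc3C(F)(F)F)cc2n1` gives 81 nM in this assay, and compound 3 `CS(=O)(=O)CCc1nc(Nc2ccc(C(F)(F)F)cc2)c2ccc(-c3ncccc3C(F)(F)F)cc2n1` gives 36 nM in this assay. Compound 2 stands at the highest number of the three: the nearest is compound 3, reached by a 2.3-fold lower number from compound 2 to compound 3 (0.35 log units; beyond the scatter), and the furthest is compound 1, from which compound 2 is reached by a 54-fold higher number from compound 1 to compound 2 (1.73 log units; beyond the scatter).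

Compound 4 `CNCc1nc(Nc2ccc(C(F)(F)F)cc2)c2ccc(-c3ncccc3C(F)(F)F)cc2n1` is not yet measured. It differs from compound 2 by methylamino in place of carboxymethoxy on a saturated chain carbon bound to an aromatic carbon. Among the compounds with values here, the steps that bear on this are the one from compound 1 to compound 2, which was large, and the one from compound 2 to compound 3, which was modest; both point the same way, toward lower numbers when the carboxymethoxy is absent. For compound 4 a lower number than compound 2 is therefore expected in this assay, with a large step of a 14-fold lower number from compound 2 to compound 4 (1.13 log units; beyond the scatter). The estimate for compound 4 is 6 nM, within a range from 1.5 nM to 25 nM.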

Compound 4, half-maximal inhibitory concentration: 26 nM
Compound 4: the middle estimate sits 4.3-fold (0.64 log units) below what was measured, and the stated range ends below it.
By their numbers in this assay, from the lowest: compound 1; then compounds 4 and 3 (each within the scatter of the next); then compound 2.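

In this assay, methylamino in place of carboxymethoxy on a saturated chain carbon bound to an aromatic carbon gives a 3.1-fold lower number from compound 2 to compound 4 (0.49 log units; beyond the scatter), yet it stays far from the methoxy of compound 1, with a 17-fold higher number from compound 1 to compound 4 (1.24 log units; beyond the scatter). Methylamino and (methylsulfonyl)methyl cannot be told apart at this place, with a 1.4-fold lower number from compound 3 to compound 4 (0.14 log units; within the scatter), while compound 1 now stands apart from all three other compounds by steps beyond the scatter, so a nitrogen-bearing group and a sulfone-bearing group read alike here. Nothing at hand accounts for these steps.

Open, from the compounds shown here alone, is whether hydroxy or ethoxy at this place would read like compound 1, and whether dimethylamino or a primary amine would read like compound 4. Also open, going by these compounds, is whether a longer chain carrying methylamino would keep the value of compound 4.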